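Swapping an aryl for an arylpropyl group on the piperazine nitrogen

The compounds below may be only part of what the source reports. "The series", "measured", "known", "first", "only" and "open" are said of these compounds alone.

Measured compounds:
compound 1, `Nc1scc(CN2CCN(c3ccc(Cl)cc3F)CC2)c1C(=O)c1ccc(Cl)cc1`, -81%
compound 2, `Nc1scc(CN2CCN(c3cccc(C(F)(F)F)c3)CC2)c1C(=O)c1ccc(Cl)cc1`, -80%
compound 3, `Nc1scc(CN2CCN(c3ccc(F)cc3F)CC2)c1C(=O)c1ccc(Cl)cc1`, -82%

In a functional assay on CHO cells with adenosine receptor A1 (Homo sapiens) as the target, read by cAMP accumulation and immunoassay, with a stated time of 6 min, tested at 10 uM (a higher number here means a weaker effect of the compound at the concentration tested, a lower number a stronger effect), compound 3 gives the lowest of the three numbers, but the gaps to compound 1 and compound 2 are both within the scatter, so no order among them can be read. Compound 4 is `Nc1scc(CN2CCN(CCCc3ccc(Cl)cc3)CC2)c1C(=O)c1ccc(Cl)cc1`; the change from compound 3 is 3-(4-chlorophenyl)propyl in place of 2,4-difluorophenyl on an amine nitrogen in a ring. The two steps that also exchange the group on this ring nitrogen, a number 1 percentage points higher from compound 1 to compound 2 (within the scatter) and a number 2 percentage points lower from compound 2 to compound 3 (within the scatter), were each within the scatter, yet both kept an aryl group directly on the nitrogen, whereas here a three-carbon chain is inserted before the ring. The account therefore expects some weakening of the read-out for compound 4, with wide uncertainty, a step of a number 17 percentage points higher from compound 3 to compound 4 (beyond the scatter) in this assay, giving an estimated value for compound 4 of -65%, within -95% to -20%.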

Compound 4, a percentage reported as activity, at one concentration (the size of the read-out at that concentration, not a potency): -76%
Beside the measured number, compound 4's estimate is 11 percentage points above it; the measured number falls inside the stated range.
By their numbers in this assay, from the lowest: compounds 3, 1, 2 and 4 (each within the scatter of the next).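

In this assay, 3-(4-chlorophenyl)propyl is the only group shown that puts a chain between the ring nitrogen and the aromatic ring, yet the read-out stays within the scatter of all three aryl compounds (a number 6 percentage points higher from compound 3 to compound 4 (within the scatter); a number 4 percentage points higher from compound 2 to compound 4 (within the scatter); a number 5 percentage points higher from compound 1 to compound 4 (within the scatter)). At this position and this one concentration, the change therefore shows no readable effect, and the four compounds cannot be ordered. Nothing measured here offers a cause for this result.

On these data alone, whether a longer chain, or an amine or a carboxylic acid at the end of the chain, would keep this read-out remains open. Any difference in potency also remains open, as a single concentration cannot show it.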